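A few compounds are considered here, and "the series" means these few. Any claim that something is new, unique, unknown or untested is made for them only; others in the source may bear on it.

Measured compounds in a physicochemical assay for acid dissociation:
- compound 1 `COc1ccc(F)cc1CNCCCNc1ccnc2cc(C3CCCCC3)ccc12` gives 9.47
- compound 2 `COc1ccc(F)cc1CNCCCNc1ccnc2cc(Oc3ccc(C(C)(C)C)cc3)ccc12` gives 9.28
- compound 3 `COc1ccc(F)cc1CNCCCNc1ccnc2cc(Cc3ccc(F)cc3Cl)ccc12` gives 9.47

Compound 3 stands level with compound 1 at the digits shown, the two together the highest of the three numbers; the step of no change at the digits printed from compound 1 to compound 3 (within the scatter) and the step of a number 0.19 log units higher from compound 2 to compound 3 (within the scatter) both lie within the scatter, so no ordering among the three is claimed.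

Compound 4 `CCC(CC)c1ccc2c(NCCCNCc3cc(F)ccc3OC)ccnc2c1` is the next member. Its change from compound 3:
pentan-3-yl in place of 2-chloro-4-fluorobenzyl on an aromatic carbon

Every measured step alters the same aromatic position while the rest of the shared core is kept, and none of them moved the number beyond the scatter: a number 0.19 log units lower from compound 1 to compound 2 (within the scatter), no change at the digits printed from compound 1 to compound 3 (within the scatter), a number 0.19 log units higher from compound 2 to compound 3 (within the scatter). Compound 1 carries cyclohexyl, an alkyl group at that position, and sits level with compound 3. The step of a number 0.02 log units lower from compound 3 to compound 4 (within the scatter) is therefore expected to be small, not beyond the scatter. Compound 4 is estimated at 9.45, with a range from 9.15 to 9.75.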

Compound 4, acid dissociation constant: 9.47
Compound 4: middle estimate off by 0.02 log units, on the low side; the range from low to high includes it.
By their numbers in this assay, from the lowest: compounds 2, 1, 3 and 4 (each within the scatter of the next).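

In this assay, the step from an aromatic-ring-bearing group to one with no ring reads no change at the digits printed from compound 3 to compound 4 (within the scatter) even though 2-chloro-4-fluorobenzyl with 9 heavy atoms gives way to pentan-3-yl with 5 heavy atoms. The open-chain group also compares with the two other groups at this aromatic carbon, with the step from cyclohexyl reading no change at the digits printed from compound 1 to compound 4 (within the scatter) and the step from 4-(tert-butyl)phenoxy reading a number 0.19 log units higher from compound 2 to compound 4 (within the scatter) in the same assay. No further measurement is available to account for this result.

Going by these compounds, whether an amine or a carboxylic acid at this aromatic carbon would move the number beyond the scatter remains open. The compounds shown vary this one place only, so the response to changes elsewhere on the shared core also remains open.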